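The source may hold more compounds than are shown below. What is called first, only, known or untested is meant among the compounds shown, and "the series" means these compounds.

Measured compounds:
Compound 1 `C[C@]1(c2ccc(Cl)cc2Cl)OC[C@@H](COc2ccc(N3CCN(c4ccc(NC(=O)c5cccnc5)cc4)CC3)cc2)O1` in an ADME assay on microsomes from liver (Homo sapiens) for metabolic stability, read by HPLC, tested at 1 uM (a lower number here means slower removal, a higher number faster removal of the compound), gives 78300 mL.min-1.g-1
Compound 2 `C[C@@]1(c2ccc(Cl)cc2Cl)OC[C@@H](COc2ccc(N3CCN(c4ccc(NC(=O)NN)cc4)CC3)cc2)O1` in this assay gives 34500 mL.min-1.g-1

Among the measured compounds shown here, of the two compounds measured so far, compound 2 stands at the lower number. Its nearest neighbour is compound 1, whose value in this assay is higher by a margin that lies beyond the usual scatter of this kind of measurement, so compound 2 is the slower-cleared of the pair.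

The step under consideration leads from compound 2 to compound 3 `C[C@]1(c2ccc(Cl)cc2Cl)OC[C@@H](COc2ccc(N3CCN(c4ccc(NC(=O)NN)cc4)CC3)cc2)O1`. The change is the two compounds have the same atoms and bonds and differ only in configuration as drawn: 1 of 2 stereo elements differ; a stereocentre at a saturated ring carbon is drawn R in compound 2 and S in compound 3. The two compounds have the same atoms and bonds and differ only in configuration as drawn: 1 of 2 stereo elements differ; a stereocentre at a saturated ring carbon is drawn R in compound 2 and S in compound 3.

For the measured compounds named here, no measured pair in this set differs by a configuration change alone, so there is no step to lean on. With the atoms and bonds unchanged, compound 3 is expected to sit close to compound 2, with the step of a 1.1-fold higher number from compound 2 to compound 3 (0.04 log units; within the scatter) expected to be no larger than the scatter and in no firm direction. Compound 3 is therefore estimated at 38000 mL.min-1.g-1, with a range from 19000 mL.min-1.g-1 to 76000 mL.min-1.g-1.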

Compound 3, intrinsic clearance in microsomes: 60400 mL.min-1.g-1
For compound 3 the middle estimate is 1.6-fold (0.20 log units) below the measured one; low and high end bracket the measured number.
By their numbers in this assay, from the lowest: compounds 2, 3 and 1 (each within the scatter of the next, the first and the last beyond it).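

Compounds 1 and 2 differ in both the configuration and the group on the carbonyl carbon, so they could not show what either change does alone; the new compound separates the two. In this assay, redrawing the stereocentre at the saturated ring carbon from R to S gives a 1.8-fold higher number from compound 2 to compound 3 (0.24 log units; within the scatter), and this step can be read as that of the stereocentre alone because nothing else changes: the fact that compounds 2 and 3 differ only in the configuration as drawn. With the S configuration held, aminoamino in place of pyridin-3-yl on the carbonyl carbon gives a 1.3-fold lower number from compound 1 to compound 3 (0.11 log units; within the scatter), so neither change taken singly resolves from the scatter in this set.

From the compounds shown here alone, it remains open whether the same change of configuration would be as small with pyridin-3-yl on the carbonyl carbon, and whether the second stereocentre behaves in the same way. Going by these compounds, how other groups on that carbonyl carbon, such as a methyl, a phenyl or a morpholine, would read in this assay also remains open.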